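The source may report more compounds than this note shows. Statements on the series, on what has been measured and on what is new or still open speak of the compounds shown alone.

In a functional assay on the whole organism for inhibition, with Mus musculus as the target, at a dose of 1 mg/kg by the oral route (on this read-out higher numbers stand for more inhibition at the one dose given (going by the name of the read-out) and lower numbers for less inhibition), compound 1, of structure `CC(C)N(C(=O)c1c(O)c2c(Cl)cccc2n(C)c1=O)c1ccccc1`, gives 54%. Compound 2, of structure `COc1cccc2c1c(O)c(C(=O)N(C)c1ccccc1F)c(=O)n2C`, gives 82% in this assay, the higher of the two numbers and a gap to compound 1 that lies beyond the usual scatter. Compound 3, of structure `COc1ccc(N(C)C(=O)c2c(O)c3c(OC)cccc3n(C)c2=O)cc1`, has not been measured. It differs from compound 2 in one place: 4-methoxyphenyl in place of 2-fluorophenyl on an amide-type nitrogen. Within the data shown here, no pair of measured compounds shows this change, so the size of its effect is unknown. The step of a number 12 percentage points lower from compound 2 to compound 3 (beyond the scatter) is expected to be small, toward less inhibition, possibly within the scatter. Compound 3 is estimated to give 70% in this assay, in a range from 45% to 90%.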

Compound 3, a percentage reported as inhibition, in the whole organism at one dose (the size of the read-out at that dose, not a potency): 84%
Beside the measured number, compound 3's estimate is 14 percentage points below it; the measured number falls inside the stated range.
By their numbers in this assay, from the lowest: compound 1; then compounds 2 and 3 (each within the scatter of the next).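

In this assay, putting 4-methoxyphenyl in place of 2-fluorophenyl on the amide-type nitrogen gives a number 2 percentage points higher from compound 2 to compound 3 (within the scatter), so these two groups cannot be told apart at this position at the one dose given. The change swaps a fluorine-bearing ring for one with a hydrogen-bond acceptor, and the read-out shows no difference beyond the scatter. Nothing at hand explains this result.

From the compounds shown here alone, it remains open how an unsubstituted phenyl would compare, or a phenyl ring carrying an amine or a carboxylic acid. Whether the two compounds would also match at other doses is equally unresolved.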